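From thiophen-3-yl to furan-2-yl on a shared core

This account rests on a few compounds, and the source may have more. Where it says the series, first, only, none or still open, it means among the compounds named here.

Measured in a functional assay on HCT-15 cells (Homo sapiens) for cytotoxicity, read by ELISA, with a stated time of 2 days; a higher number here means a weaker inhibitor, a lower number a stronger inhibitor:
compound 1 `Oc1ccc(-c2cc(-c3ccccc3)cc(-c3ccccc3)n2)cc1`: 3700 nM
compound 2 `Oc1ccc(-c2cc(-c3ccccc3)cc(-c3ccsc3)n2)cc1`: 1100 nM

Compound 2 holds the lower of the two numbers, and its gap to compound 1 lies beyond the scatter. Compound 3 `Oc1ccc(-c2cc(-c3ccccc3)cc(-c3ccco3)n2)cc1` differs from compound 2 at one place: furan-2-yl in place of thiophen-3-yl on an aromatic carbon. Within the data shown here, the only measured step bearing on this is a 3.4-fold lower number from compound 1 to compound 2 (0.53 log units; beyond the scatter), a modest change at the same place. Among the measured compounds shown here, no measured compound carries furan-2-yl, so this step gives only a rough size. In this assay, a slightly higher number is expected, but no step beyond the scatter. The expected step is a 1.4-fold higher number from compound 2 to compound 3 (0.13 log units; within the scatter). For compound 3, the estimate is 1500 nM, with an expected range of 500 nM to 4500 nM.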

Compound 3, half-maximal inhibitory concentration: 3500 nM
The estimate for compound 3 lay 2.3-fold (0.37 log units) below the measured number; the range from low to high includes it.
By their numbers in this assay, from the lowest: compound 2; then compounds 3 and 1 (each within the scatter of the next).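

In this assay, the gain seen with thiophen-3-yl at this position does not extend to furan-2-yl, although both are five-membered aromatic rings with one hetero atom: the swap gives a 3.2-fold higher number from compound 2 to compound 3 (0.50 log units; beyond the scatter) and places compound 3 back level with compound 1. The step for furan-2-yl in place of phenyl is a 1.1-fold lower number from compound 1 to compound 3 (0.02 log units; within the scatter) and so shows no difference. No evidence is available to explain the result. Open, going by these compounds, is whether the hetero atom or the point of attachment matters, since both change here. Thiophen-2-yl and furan-3-yl would separate these two.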